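The compounds below may be only part of what the source reports. "The series", "measured", "known", "first", "only" and "open" are said of these compounds alone.

Measured in a toxicity assay on MT4 cells (Homo sapiens) for cytotoxicity, read by MTT assay, with a stated time of 5 days; a higher number here means that more compound is tolerated, a lower number that less compound is tolerated:
- compound 1 `Cc1cc(-c2cccs2)cc(C)c1Nc1ccnc(Nc2ccc(C#N)cc2)n1`: 10000 nM
- compound 2 `Cc1cc(-c2cncnc2)cc(C)c1Nc1ccnc(Nc2ccc(C#N)cc2)n1`: 6800 nM
- compound 3 `Cc1cc(-c2cccc3cc[nH]c23)cc(C)c1Nc1ccnc(Nc2ccc(C#N)cc2)n1`: 1000 nM

Compound 3 holds the lowest number of the three, with a 6.8-fold lower number from compound 2 to compound 3 (0.83 log units; beyond the scatter) and a 10-fold lower number from compound 1 to compound 3 (1.00 log units; beyond the scatter), both beyond the scatter. Compound 4 `Cc1cc(-c2cc(C)c(Nc3ccnc(Nc4ccc(C#N)cc4)n3)c(C)c2)ccn1` carries 2-methylpyridin-4-yl in place of 1H-indol-7-yl on an aromatic carbon. Within the data shown here, no measured compound carries the entering group. The nearest evidence is a 1.5-fold lower number from compound 1 to compound 2 (0.17 log units; within the scatter), within the scatter, which suggests that the two non-indole groups sit close together. A step upward, somewhat smaller than those two larger steps, is therefore expected in this assay. The estimate is a 5.0-fold higher number from compound 3 to compound 4 (0.70 log units; beyond the scatter). Compound 4 is expected at 5000 nM, with an estimated range of 1800 nM to 13000 nM.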

Compound 4, half-maximal cytotoxic concentration: 4900 nM
For compound 4 the middle estimate is 1.0-fold (0.01 log units) above the measured one; the range from low to high includes it.
By their numbers in this assay, from the lowest: compound 3; then compounds 4, 2 and 1 (each within the scatter of the next, the first and the last beyond it).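

In this assay, 2-methylpyridin-4-yl in place of 1H-indol-7-yl (a 4.9-fold higher number from compound 3 to compound 4 (0.69 log units; beyond the scatter)) gives a third group at this position that stands clear of compound 3. Against pyrimidin-5-yl the change stays small (a 1.4-fold lower number from compound 2 to compound 4 (0.14 log units; within the scatter)), but against thiophen-2-yl it just passes the scatter (a 2.0-fold lower number from compound 1 to compound 4 (0.31 log units; beyond the scatter)), so the non-indole groups do not all lie within the scatter of one another. No supporting data bear on these differences.

Going by these compounds, whether the gap follows the whole 1H-indol-7-yl group or only its hydrogen-bond donor stays open. On these data alone, how an amine or a carboxylic acid on this carbon would read is also open.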